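From Acetyl to Dimethylamino: One Step From a Limit

This account rests on a few compounds, and the source may have more. Where it says the series, first, only, none or still open, it means among the compounds named here.

Of the compounds shown here, two have been tested in a functional assay on LOX IMVI cells (Homo sapiens) for inhibition, read by sulforhodamine B assay, with a stated time of 48 h; on this read-out higher numbers stand for weaker inhibition of growth and lower numbers for stronger inhibition of growth. Compound 1 `COc1cc(C)cc(-c2c(-c3ccnc(-c4ccc(C(C)=O)cc4)c3)cnn2CC#N)c1` does not reach a number: in this assay compound 1 gives > 100000 nM, which is a limit of the assay. Compound 2 `Cc1cc(O)cc(-c2nn(CC#N)cc2-c2ccnc(-c3ccc(Oc4ccccc4)cc3)c2)c1` differs from compound 1 in several places at once, and in this assay compound 2 gives 3390 nM. Among the measured compounds shown here, no pair of measured compounds differs in a single place, so compound 1 stands only at the limit of > 100000 nM in this assay, at which 1 of the 2 values shown sits, with no measured neighbour to place it more closely.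

Compound 3 `COc1cc(C)cc(-c2c(-c3ccnc(-c4ccc(N(C)C)cc4)c3)cnn2CC#N)c1` is the untested compound. It departs from compound 1 by dimethylamino in place of acetyl on an aromatic carbon. Nothing measured here shows how such an exchange is felt in this assay, and the starting point is itself a limit. The expected step is therefore an at least 2.5-fold lower number from compound 1 to compound 3 (0.39 log units; beyond the scatter), which could be anything from no change beyond the scatter to a gain in growth inhibition. Compound 3 is estimated at 40000 nM, within a range from 5000 nM to 150000 nM, with a real chance that the assay again reports only a limit.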

Compound 3, concentration for total growth inhibition: > 100000 nM
Compound 3: no number, only a limit; the forecaster's own chance of this, stated with the estimate: 50%; middle value at least 2.5-fold (0.39 log units) away from the limit.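

Among the compounds shown here, compound 1 and compound 3 both give only a limit in this assay, so no step from acetyl to dimethylamino can be read between them: the limit of > 100000 nM in this assay, at which 2 of the 3 values shown sit. The compounds shown leave open whether dimethylamino in place of acetyl changes the inhibition of growth at all.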